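The compounds below may be only part of what the source reports. "The series", "measured", "known", "first", "only" and "open" are said of these compounds alone.

Measured compounds:
compound 1 `COc1cc(N2C(=O)CC2c2ccc(SC)cc2)cc(OC)c1OC` — 67 nM
compound 2 `COc1ccc(C2C(O)C(=O)N2c2cc(OC)c(OC)c(OC)c2)cc1` — 4 nM

In a functional assay on MCF7 cells (Homo sapiens) for inhibition, read by resazurin assay, with a stated time of 72 h (on this read-out higher numbers stand for weaker inhibition and lower numbers for stronger inhibition), compound 2 gives 4 nM, the lowest of the two numbers recorded. Compound 1 gives 67 nM in this assay, a higher number, and the gap between them lies beyond the usual scatter. For the measured compounds named here, no single-point step between the two measured compounds is available, so what they show is only that compound 2 stands at the stronger end.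

Compound 3 `CCSc1ccc(C2C(O)C(=O)N2c2cc(OC)c(OC)c(OC)c2)cc1` has not been measured. Relative to compound 2 the change is ethylsulfanyl in place of methoxy on an aromatic carbon. The shared core is kept. Whether ethylsulfanyl in this place is tolerated cannot be read from compound 1, which differs from compound 2 elsewhere as well. A moderate loss of potency is expected, the step from compound 2 to compound 3 in this assay being estimated at a 5.0-fold higher number from compound 2 to compound 3 (0.70 log units; beyond the scatter). Compound 3 is accordingly expected to give about 20 nM in this assay, within a range of 5 nM to 80 nM.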

Compound 3, half-maximal inhibitory concentration: 6 nM
Compound 3: middle estimate off by 3.3-fold (0.52 log units), on the high side; low and high end bracket the measured number.
By their numbers in this assay, from the lowest: compounds 2 and 3 (each within the scatter of the next); then compound 1.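

Ethylsulfanyl in place of methoxy on this aromatic carbon, para to a large group, gives a 1.5-fold higher number from compound 2 to compound 3 (0.18 log units; within the scatter) in this assay, so the two groups cannot be told apart on this read-out. The position therefore accepts ethylsulfanyl as well as methoxy in this series, which compound 1 could not show, since it differs from compound 2 in more than one place. Nothing at hand gives a reason for this outcome.

As far as these compounds go, how far the position accepts other groups stays open, whether a longer chain such as butylsulfanyl, an amine or a carboxylic acid. Also open, from the compounds shown here alone, is what the hydroxy group on the shared core of compound 2 and compound 3 contributes, as compound 1 lacks it but differs elsewhere too.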